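A Naphthyl Thioether in Place of the Trifluoromethylbenzyl

The source may hold more compounds than are shown below. What is called first, only, known or untested is meant among the compounds shown, and "the series" means these compounds.

Among the compounds with values here, compound 3 `C/C(C#Cc1ccccc1)=N\N/C(N)=N/S(=O)(=O)c1cc(C)c(Cl)cc1SCc1ccccc1C(F)(F)F` gives 23000 nM in a functional assay on HCT-116 cells (Homo sapiens) for antiproliferative activity, read by MTT assay, with a stated time of 72 h (on this read-out higher numbers stand for weaker inhibition and lower numbers for stronger inhibition), and stands highest among the compounds measured so far. Compound 2 `Cc1cc(S(=O)(=O)/N=C(\N)N/N=C/C#Cc2ccccc2)c(SCc2ccccc2C(F)(F)F)cc1Cl` gives 18000 nM in this assay, and compound 1 `Cc1cc(S(=O)(=O)/N=C(\N)N/N=C/C#Cc2ccccc2)c(SCc2ccccc2)cc1Cl` gives 8000 nM. The step of a 1.3-fold higher number from compound 2 to compound 3 (0.11 log units; within the scatter) lies within the scatter, while the step of a 2.3-fold higher number from compound 1 to compound 2 (0.35 log units; beyond the scatter) is modest and beyond it.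

Compound 4 `C/C(C#Cc1ccccc1)=N\N/C(N)=N/S(=O)(=O)c1cc(C)c(Cl)cc1SCc1cccc2ccccc12` differs from compound 3 by naphthalen-1-yl in place of 2-(trifluoromethyl)phenyl on a saturated chain carbon bound to a sulfur. Within the data shown here, the step from compound 1 to compound 2 concerns the same part of the molecule and shows that adding a trifluoromethyl there raised the number; whether taking it away while fusing a second aromatic ring to the benzyl reverses that is not told by any measured pair, since no compound carries a fused ring at this position. Compound 4 is therefore expected to show a step of a 1.3-fold lower number from compound 3 to compound 4 (0.11 log units; within the scatter), which is within the scatter. The estimate for compound 4 in this assay is 18000 nM, with a range from 7000 nM to 45000 nM.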

Compound 4, half-maximal inhibitory concentration: 105000 nM
Compound 4: middle estimate off by 5.8-fold (0.77 log units), on the low side; the whole stated range lies below it.
By their numbers in this assay, from the lowest: compound 1; then compounds 2 and 3 (each within the scatter of the next); then compound 4.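

Naphthalen-1-yl in place of 2-(trifluoromethyl)phenyl on a saturated chain carbon bound to a sulfur gives a 4.6-fold higher number from compound 3 to compound 4 (0.66 log units; beyond the scatter) in this assay and so marks this group as more than a small change at this place. Together with a 2.3-fold higher number from compound 1 to compound 2 (0.35 log units; beyond the scatter) on the same part of the molecule, it means that both changes read here at this place raised the number, and neither lowered it. Nothing available explains why the fused second ring carries this cost.

The compounds shown do not separate the loss of the trifluoromethyl from the gain of the second ring. On these data alone, how naphthalen-2-yl, which would keep the two rings but attach them differently, or a pyridine ring, which would put a nitrogen into the aromatic ring, would read at this place remains open.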